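Swapping a cyclopropylmethoxy for fluoro on a styryl chromone

This account rests on a few compounds, and the source may have more. Where it says the series, first, only, none or still open, it means among the compounds named here.

Of the compounds shown here, three have been measured in a functional assay on HeLa cells (Homo sapiens) for antiproliferative activity, read by MTT assay, with a stated time of 12 h; on this read-out higher numbers stand for weaker inhibition and lower numbers for stronger inhibition. Compound 1 `COc1cc(OC)c2c(=O)cc(/C=C/c3ccncc3)oc2c1` gives 18800 nM in this assay, compound 2 `COc1cc(OC)c2c(=O)cc(/C=C/c3ccc(OCC4CC4)cc3)oc2c1` gives 10900 nM, and compound 3 `COc1ccc2c(=O)cc(/C=C/c3ccc(OC(F)(F)F)cc3)oc2c1` gives 9900 nM. Among these three numbers compound 2 holds the second highest; its nearest neighbour is compound 3 and its furthest is compound 1, and both gaps fall within the usual scatter, so no order among the three can be read from them. Compound 4 `COc1cc(OC)c2c(=O)cc(/C=C/c3ccc(F)cc3)oc2c1` has not yet been measured. It differs from compound 2 by fluoro in place of cyclopropylmethoxy on an aromatic carbon, on an aromatic carbon of a six-membered aromatic ring of carbon only. Among the compounds with values here, no step between measured compounds describes this kind of change, so nothing in the measured set anchors its size or direction. With all three known numbers close together at a weak level, compound 4 is expected to land near them, with a step from compound 2 of a 1.2-fold higher number from compound 2 to compound 4 (0.08 log units; within the scatter) that stays within the scatter. The estimate for compound 4 in this assay is 13000 nM, within a range from 5000 nM to 35000 nM.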

Compound 4, half-maximal inhibitory concentration: 14200 nM
Compound 4: middle estimate off by 1.1-fold (0.04 log units), on the low side; measured number inside the range.
By their numbers in this assay, from the lowest: compounds 3, 2, 4 and 1 (each within the scatter of the next).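

In this assay, fluoro in place of cyclopropylmethoxy gives a 1.3-fold higher number from compound 2 to compound 4 (0.11 log units; within the scatter), so at this position the five-heavy-atom group bearing a three-membered ring and the single fluorine cannot be told apart. The aryl end of the styryl chain shows the same picture: 4-fluorophenyl in place of pyridin-4-yl gives a 1.3-fold lower number from compound 1 to compound 4 (0.12 log units; within the scatter), which again stays within the scatter. No accompanying data bear on why these exchanges leave the read-out so little changed.

On these data alone, whether an amine, a carboxylic acid or a longer alkoxy chain at this position would move the number beyond the scatter remains open. Also open, as far as these compounds go, is what the methoxy groups on the core contribute, since compound 3 differs from the others in more than one place and so offers no clean comparison.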